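This account rests on a few compounds, and the source may have more. Where it says the series, first, only, none or still open, it means among the compounds named here.

Three compounds sharing one core anchor this series in a functional assay on HL-60 cells (Homo sapiens) for antiproliferative activity, read by MTT assay, with a stated time of 72 h; on this read-out lower numbers stand for stronger inhibition and higher numbers for weaker inhibition. Compound 1 (`Cc1ccc(S(=O)(=O)NC(=N)N2CCN(c3cc4c(cc3F)c(=O)c(C(=O)O)cn4C3CC3)CC2)cc1`) gives 43 nM, compound 2 (`N=C(NS(=O)(=O)c1ccc(Cl)cc1)N1CCN(c2cc3c(cc2F)c(=O)c(C(=O)O)cn3C2CC2)CC1`) gives 43 nM, and compound 3 (`N=C(NS(=O)(=O)c1ccccc1C(F)(F)F)N1CCN(c2cc3c(cc2F)c(=O)c(C(=O)O)cn3C2CC2)CC1`) gives 43 nM, so compound 1 stands level with both. The next compound, compound 4 (`CCn1cc(C(=O)O)c(=O)c2cc(F)c(N3CCN(C(=N)NS(=O)(=O)c4ccc(C)cc4)CC3)cc21`), keeps the 4-methylphenyl on the sulfonyl sulfur of compound 1 but carries ethyl in place of cyclopropyl on an aromatic nitrogen.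

The measured steps bear on this change only indirectly. Chloro in place of methyl on an aromatic carbon gave no change at the digits printed from compound 1 to compound 2 (within the scatter). The 2-(trifluoromethyl)phenyl group gave no change at the digits printed from compound 1 to compound 3 (within the scatter) in place of 4-methylphenyl and no change at the digits printed from compound 2 to compound 3 (within the scatter) in place of 4-chlorophenyl on a sulfonyl sulfur. Going by the values given here, all three steps lie within the scatter, yet none touches the aromatic nitrogen, and the data hold no measured step at that place. The expectation therefore starts from compound 1 at 43 nM and has to stay wide. No shift beyond the scatter is expected, and the expected step is a 1.3-fold higher number from compound 1 to compound 4 (0.11 log units; within the scatter). Compound 4 is estimated at 55 nM, with an expected range from 20 nM to 150 nM.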

Compound 4, half-maximal inhibitory concentration: 43 nM
Beside the measured number, compound 4's estimate is 1.3-fold (0.11 log units) above it; measured number inside the range.
By their numbers in this assay, from the lowest: compounds 1, 2, 3 and 4 (each within the scatter of the next).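

Going by these compounds alone, the step at the aromatic nitrogen, no change at the digits printed from compound 1 to compound 4 (within the scatter), is the first one in this assay taken at this position, ethyl in place of cyclopropyl. The earlier steps shown here changed only the aryl group on the sulfonyl sulfur, whereas this one shows that the read-out also stays within the scatter when the three-membered ring of carbon only gives way to an open ethyl group in a second place on the molecule. Among the four compounds, therefore, neither place has yet produced a step beyond the scatter, and no information accompanying these numbers accounts for that flat result.

What the compounds shown leave open is how far this position can be pushed, for instance with a longer chain such as n-butyl, a benzyl group or a 2-hydroxyethyl group on the aromatic nitrogen, and whether ethyl behaves the same way when paired with the 4-chlorophenyl or 2-(trifluoromethyl)phenyl group on the sulfonyl sulfur. They also leave open whether any change elsewhere on the shared core, such as an amide in place of the carboxylic acid, would move the number beyond the scatter.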